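The source may report more compounds than this note shows. Statements on the series, on what has been measured and on what is new or still open speak of the compounds shown alone.

Measured so far in an assay on mitochondria for inhibition of Amine oxidase [flavin-containing] B (Bos taurus), read by fluorescence, with a stated time of 60 min; on this read-out higher numbers stand for weaker inhibition and lower numbers for stronger inhibition:

- compound 1, `COC(=O)CN1C(=O)c2ccccc2NC1c1ccc(OC)cc1`: 560000 nM
- compound 2, `COc1ccc(C2Nc3ccccc3C(=O)N2CC(=O)NN)cc1`: 890000 nM
- compound 3, `COC(=O)CCN1C(=O)c2ccccc2NC1c1ccccc1`: 860000 nM

Compound 1 and compound 2 differ in one place: aminoamino in place of methoxy on a carbonyl carbon. In this assay that change gave a 1.6-fold higher number from compound 1 to compound 2 (0.20 log units; within the scatter), so the two numbers sit within the usual scatter of each other. Compound 3 stands within the scatter of both compound 1 and compound 2, and no order among the three is claimed. The difference between the core of compound 1 and the core of compound 3 is not broken down here.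

Compound 4, `NNC(=O)CCN1C(=O)c2ccccc2NC1c1ccccc1`, is not yet measured. It differs from compound 3 by aminoamino in place of methoxy on a carbonyl carbon. The surroundings of the place are described in the same words as for the earlier pair, so this is the same change made once more, now on the core of compound 3. Going by the values given here, the only precedent is the step from compound 1 to compound 2, which stayed within scatter, so a step of similar size is expected: a 1.4-fold higher number from compound 3 to compound 4 (0.14 log units; within the scatter). The estimate for compound 4 in this assay is 1200000 nM, expected to fall between 500000 nM and 3000000 nM. Among the compounds with values here, this rests on compound 3 at 860000 nM together with the step of a 1.6-fold higher number from compound 1 to compound 2 (0.20 log units; within the scatter), and on nothing more, since only one earlier instance of the change exists.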

Compound 4, half-maximal inhibitory concentration: 210000 nM
The estimate for compound 4 lay 5.7-fold (0.76 log units) above the measured number; the whole stated range lies above it.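

In this assay, aminoamino in place of methoxy on a carbonyl carbon gives a 4.1-fold lower number from compound 3 to compound 4 (0.61 log units; beyond the scatter), so the change does not carry over unaltered from the core of compound 1 to the core of compound 3: the same change on two cores in this assay, a 1.6-fold higher number (0.20 log units; within the scatter) from compound 1 to compound 2 and a 4.1-fold lower number (0.61 log units; beyond the scatter) from compound 3 to compound 4, 6.5-fold (0.81 log units) apart, beyond the scatter of two such steps

On the core of compound 3, the 2-(aminocarbamoyl)ethyl group goes with stronger inhibition than the 2-(methoxycarbonyl)ethyl group, whereas the same swap on the core of compound 1 stays within the scatter, so the outcome of this change depends on the core in these two pairs. The two cores differ in more than one place, and two pairs do not show which difference between them matters, nor how the change would behave on any further core.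

The compounds shown leave open how a carboxylic acid or a primary amide on the same carbonyl carbon would read on either core. They also leave open whether a longer chain carrying the aminocarbamoyl group would shift the number further.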